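Working notes: extending the ester chain of compound 1

The source may report more compounds than this note shows. Statements on the series, on what has been measured and on what is new or still open speak of the compounds shown alone.

In a functional assay on HeLa cells (Homo sapiens) for cytotoxicity, read by cell counting, with a stated time of 48 h (a higher number here means that more compound is needed for the effect, a lower number that less compound is needed), compound 1 `CCCCCCCCCC(=O)O[C@H]1[C@H](O)[C@H](n2ccc(N)nc2=O)O[C@@H]1CO` gives 0.09 ug/mL. Compound 2 `CCCC(=O)OC[C@H]1O[C@@H](n2ccc(N)nc2=O)[C@@H](O)[C@@H]1OC(=O)CCC` gives 0.11 ug/mL, and compound 3 `CCCCCCCCCC(=O)OC[C@H]1O[C@@H](n2ccc(N)nc2=O)[C@@H](O)[C@@H]1OC(=O)CCCCCCCCC` gives 0.11 ug/mL. All three values lie within the scatter of one another, so compound 1 has no distinct standing in this small set.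

The next compound is compound 4 `CCCCCCCCCCCCCC(=O)O[C@H]1[C@H](O)[C@H](n2ccc(N)nc2=O)O[C@@H]1CO`, and the structural change is butyl in place of hydrogen on a saturated chain carbon, nine bonds along the chain from a carbonyl carbon. Within the data shown here, no measured step makes this same change. Among the measured compounds shown here, the one step that bears on it is a 1.2-fold higher number from compound 1 to compound 3 (0.09 log units; within the scatter), a different change that stays within the scatter despite the added nonylcarbonyl. On that thin evidence, no step beyond the scatter is expected in this assay. The estimated step is a 1.2-fold higher number from compound 1 to compound 4 (0.09 log units; within the scatter), which is expected to remain within the scatter. For compound 4 the expected value is 0.11 ug/mL, with an estimated range of 0.05 ug/mL to 0.3 ug/mL.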

Compound 4, concentration for half-maximal effect: 0.08 ug/mL
Compound 4: the middle estimate sits 1.4-fold (0.14 log units) above what was measured, and the stated range covers the measured number.
By their numbers in this assay, from the lowest: compounds 4, 1, 2 and 3 (each within the scatter of the next).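

In this assay, butyl in place of hydrogen on a saturated chain carbon, nine bonds along the chain from a carbonyl carbon, gives a 1.1-fold lower number from compound 1 to compound 4 (0.05 log units; within the scatter). The earlier compounds shown here gave no direct reading of this change; this step shows that the ester chain of compound 1 carries the added butyl with no step beyond the scatter. Nothing measured bears on why the number holds at this position.

Among these compounds, still open is whether a longer chain than the one in compound 4 would also stay within the scatter, or whether the flat reading has a limit at some chain length. Also open, as far as these compounds go, is whether an amine or a carboxylic acid on this chain, in place of hydrogen at the same carbon, would give a step beyond the scatter.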